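Swapping the ethylphenyl arm for a chlorohydroxyphenyl

A few compounds are considered here, and "the series" means these few. Any claim that something is new, unique, unknown or untested is made for them only; others in the source may bear on it.

Compounds measured so far:
compound 1, `Oc1ccc2ccncc2c1C(c1ccc(F)cc1)N1CCCCC1`: 10200 nM
compound 2, `CCc1ccc(C(Nc2ccccn2)c2ccc3cccnc3c2O)cc1`: 170 nM

Within the data shown here, in an assay for inhibition of protein disulfide-isomerase (Homo sapiens), with a stated time of 1 h (on this read-out higher numbers stand for weaker inhibition and lower numbers for stronger inhibition), compound 2 gives 170 nM, the lowest of the two numbers recorded, and the only neighbour, compound 1, sits at a higher number that lies beyond the scatter. Among the measured compounds shown here, the two compounds differ in several places at once, so the comparison shows only that compound 2 inhibits more strongly.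

Compound 3, `Oc1cccc(C(Nc2ccccn2)c2ccc3cccnc3c2O)c1Cl`, keeps the shared core and the pyridinylamino group of compound 2 and changes one arm: 2-chloro-3-hydroxyphenyl in place of 4-ethylphenyl on a saturated chain carbon bound to an aromatic carbon and a nitrogen on an aromatic ring. For the measured compounds named here, no measured pair shows what such a change does here, so the expectation is for a step that stays within, or only just beyond, the scatter, leaning toward a slightly higher number. The step from compound 2 to compound 3 is estimated as a 1.8-fold higher number from compound 2 to compound 3 (0.25 log units; within the scatter). For compound 3 in this assay the expected result is 300 nM, with a likely range from 80 nM to 1500 nM.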

Compound 3, half-maximal inhibitory concentration: 370 nM
For compound 3 the middle estimate is 1.2-fold (0.09 log units) below the measured one, within the range that was stated.
By their numbers in this assay, from the lowest: compound 2; then compound 3; then compound 1.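

Placed on a saturated chain carbon bound to an aromatic carbon and a nitrogen on an aromatic ring, 2-chloro-3-hydroxyphenyl in place of 4-ethylphenyl gives a 2.2-fold higher number from compound 2 to compound 3 (0.34 log units; beyond the scatter) in this assay and that modest step lies just beyond the scatter. Among these compounds, this is the first comparison here that changes only one place, and it shows that this position tolerates an arm bearing a hydrogen-bond donor and acceptor, with compound 3 losing only a little inhibition relative to compound 2. No measurement on hand explains the rise in the number.

Going by these compounds, the chlorine and the hydroxyl enter together, so what each contributes on its own stays open. On these data alone, it also remains unknown how this position would respond to an arm carrying a carboxylic acid or an amine.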